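The source may hold more compounds than are shown below. What is called first, only, known or untested is meant among the compounds shown, and "the series" means these compounds.

The three measured compounds share one core and differ in one or two places. In a functional assay on JAR cells (Homo sapiens) for inhibition, read by MTT assay, with a stated time of 72 h, tested at 10 uM (on this read-out higher numbers stand for more inhibition at the one concentration tested (going by the name of the read-out) and lower numbers for less inhibition), compound 1, `CCOC(=O)C1=C(Nc2ccccc2)S/C(=C\c2ccccc2)C1=O`, gives 20.3%. Compound 2, `CCOC(=O)C1=C(Nc2ccccc2)S/C(=C\c2ccc(OC)cc2)C1=O`, carries methoxy in place of hydrogen on an aromatic carbon and in this assay compound 2 gives 32.9%, a step of a number 12.6 percentage points higher from compound 1 to compound 2 (beyond the scatter). Compound 3, `CCOC(=O)C1=C(Nc2ccccc2)S/C(=C\c2ccc[nH]2)C1=O`, differs from compound 1 in its core by 1H-pyrrol-2-yl in place of phenyl on a double-bonded chain carbon bound to a double-bonded ring carbon, and in this assay compound 3 gives 49.2%. That is a number 28.9 percentage points higher from compound 1 to compound 3 (beyond the scatter) and a number 16.3 percentage points higher from compound 2 to compound 3 (beyond the scatter), so compound 3 stands highest of the three, with both steps beyond the scatter.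

Compound 4, `CCOC(=O)C1=C(Nc2ccc(OC)cc2)S/C(=C\c2ccc[nH]2)C1=O`, has not yet been measured. It differs from compound 3 by methoxy in place of hydrogen on an aromatic carbon. The same change, at the same place, was made once before, from compound 1 to compound 2, where it gave a number 12.6 percentage points higher from compound 1 to compound 2 (beyond the scatter). The core on which it is now made differs from the earlier one as described above, by the change from compound 1 to compound 3, so the earlier step is a guide rather than a rule.

From compound 3 to compound 4 the step is expected to be a number 10.8 percentage points higher from compound 3 to compound 4 (beyond the scatter). This expectation rests on compound 1 and compound 2, where the same change gave a number 12.6 percentage points higher from compound 1 to compound 2 (beyond the scatter), and on that single example alone. Compound 4 is therefore estimated at 60%, with a likely range from 45% to 75%.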

Compound 4, a percentage reported as inhibition, at one concentration (the size of the read-out at that concentration, not a potency): 27.6%
Estimate against measurement, compound 4: 32.4 percentage points above; the measured number lies below the stated range.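

In this assay, methoxy in place of hydrogen on an aromatic carbon gives a number 21.6 percentage points lower from compound 3 to compound 4 (beyond the scatter), so the direction of the change did not carry over from the core of compound 1 to the core of compound 3: the same change on two cores in this assay, a number 12.6 percentage points higher (beyond the scatter) from compound 1 to compound 2 and a number 21.6 percentage points lower (beyond the scatter) from compound 3 to compound 4, 34.2 percentage points apart, beyond the scatter of two such steps This shows that, in these two pairs, the outcome of adding methoxy depends on the rest of the molecule, and that a step seen on one core cannot simply be added to a value on another. For the compounds shown here, it does not show which structural difference between the two cores is responsible, why the sign flips, or how other cores would respond, since the comparison rests on only two pairs, each read at a single concentration in one cell line.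

The compounds shown leave open how a smaller or differently built group, such as a fluorine atom, a hydroxyl group or an amine, would behave in place of that same hydrogen on each of the two cores. They also leave open what would happen if the ethyl ester gave way to a carboxylic acid or an amide, or if the 1H-pyrrol-2-yl group gave way to a furan ring.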